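The compounds below may be only part of what the source reports. "The series", "measured", "known", "first", "only" and "open" are said of these compounds alone.

Measured so far in a functional assay on a cell-free system (plasma) for inhibition of thromboxane A2 receptor (Homo sapiens), read by turbidimetry; a higher number here means a weaker inhibitor, a lower number a stronger inhibitor:
compound 1 `Cc1ccc(S(=O)(=O)N[C@H]2CC[C@@H](F)[C@@H]2CCCCOCC(=O)O)cc1`: 1800 nM
compound 2 `O=C(O)CC/C=C\C[C@@H]1[C@@H](CNS(=O)(=O)c2ccc(F)cc2)CC[C@H]1F`: 1900 nM; 1900 nM; 650 nM (3 entries)
compound 3 `O=C(O)CC/C=C\CC1=CCC[C@@H]1NS(=O)(=O)c1ccccc1`: 2200 nM

Compound 3 carries the highest of the two single numbers in this assay. Compound 1 sits nearest, with a lower value that still lies within the scatter, so no order between compound 1 and compound 3 can be read from these two entries. Compound 2 gives no single number to rank against them, having several entries, (the several entries of compound 2 in this assay, 1900 nM; 1900 nM; 650 nM (3 entries)).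

Compound 4 `O=C(O)CCC/C=C\CC1=CCC[C@@H]1NS(=O)(=O)c1ccccc1` has not yet been measured in this assay. It differs from compound 3 in one place: carboxymethyl in place of carboxy on a saturated chain carbon, two bonds along the chain from a double-bonded chain carbon. For the measured compounds named here, no step between measured compounds covers this change, so nothing measured fixes its size or direction. The expectation is for a modest step, toward a weaker inhibitor if anything, with a fair chance that it does not clear the scatter: from compound 3 to compound 4 a 1.2-fold higher number from compound 3 to compound 4 (0.07 log units; within the scatter) is expected. On that basis compound 4 is estimated at 2600 nM, with a range from 800 nM to 8000 nM.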

Compound 4, half-maximal inhibitory concentration: 2300 nM
Estimate against measurement, compound 4: 1.1-fold (0.05 log units) above; low and high end bracket the measured number.
By their numbers in this assay, from the lowest: compounds 1, 3 and 4 (each within the scatter of the next).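

For the compounds shown here, the first one-place step concerns the acid-bearing chain: in this assay, carboxymethyl in place of carboxy on a saturated chain carbon, two bonds along the chain from a double-bonded chain carbon, gives a 1.0-fold higher number from compound 3 to compound 4 (0.02 log units; within the scatter). The 4-carboxybut-1-en-1-yl and 5-carboxypent-1-en-1-yl chains therefore cannot be told apart in this read-out on this core, and the step gives no direction for chain length at this position. Repeat entries elsewhere in the series also show how widely numbers can spread in this read-out, so a step this small should not be over-read: the several entries of compound 2 in this assay, 1900 nM; 1900 nM; 650 nM (3 entries)

This single step does not show whether the same holds on the other cores shown. From the compounds shown here alone, a longer chain ending in a carboxylic acid, or a tetrazole in place of the carboxylic acid, remains open at this position.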